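A trifluoromethyl chain end on compound 3

The source may hold more compounds than are shown below. What is called first, only, known or untested is meant among the compounds shown, and "the series" means these compounds.

Compound 1 `CCCCn1nc(C(=O)N[C@H]2COc3ccccc3N(C)C2=S)nc1Cc1ccccc1` gives > 100000 nM as a limit
Compound 2 `CCCCCn1nc(C(=O)N[C@H]2COc3ccccc3N(C)C2=S)nc1Cc1ccccc1` gives > 100000 nM as a limit
Compound 3 `CC(C)CCn1nc(C(=O)N[C@H]2COc3ccccc3N(C)C2=S)nc1Cc1ccccc1` gives > 100000 nM as a limit

In a toxicity assay on HT-29 cells (Homo sapiens) for cytotoxicity (on this read-out lower numbers stand for higher toxicity in this test and higher numbers for lower toxicity in this test), compound 3 gives > 100000 nM as its read-out, and this is a limit of the assay, not a number. Compound 1 and compound 2 also report only limits, so compound 3 has no rank among them, and the whole set rests on the limit of > 100000 nM in this assay, at which 3 of the 3 values shown sit, and nothing finer.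

Compound 4 `CN1C(=S)[C@@H](NC(=O)c2nc(Cc3ccccc3)n(CCC(F)(F)F)n2)COc2ccccc21` differs from compound 3 by trifluoromethyl in place of isopropyl on a saturated chain carbon, two bonds along the chain from an aromatic nitrogen in one place, with trifluoromethyl in place of isopropyl on a saturated chain carbon, two bonds along the chain from an aromatic nitrogen. The nearest measured evidence is a step that the two limits leave unreadable from compound 2 to compound 3 at that same place, and a step that the two limits leave unreadable from compound 1 to compound 2 and a step that the two limits leave unreadable from compound 1 to compound 3 are changes in the same chain. Going by the values given here, none of these has a readable size, so they support no step of definite size in this assay and no direction. The expected step is a number no higher from compound 3 to compound 4 (the limit leaves the size open) and it carries no direction beyond the scatter. For compound 4 the estimate is 100000 nM with a range from 50000 nM to 200000 nM and the assay is expected to report a limit again.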

Compound 4, half-maximal cytotoxic concentration: > 100000 nM
Compound 4 was reported as a limit (the forecaster's own chance of this, stated with the estimate: 85%); the middle value sits exactly at the limit.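

In this assay compound 4 gives > 100000 nM, which is a limit. The steps to compound 4 from compound 1, compound 2 and compound 3 therefore cannot be read, in size or in direction. The compounds shown leave open whether any chain at this place changes the read-out, because the whole set rests on a single limit: the limit of > 100000 nM in this assay, at which 4 of the 4 values shown sit.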